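Trifluoromethyl to Fluoro: Following Compound 1 to Compound 4

The source may report more compounds than this note shows. Statements on the series, on what has been measured and on what is new or still open speak of the compounds shown alone.

compound 1 `O=c1ccc(-c2ccc3cn[nH]c3c2)cn1Cc1ccccc1C(F)(F)F`: 100 nM
compound 2 `CC(=O)Nc1cccc(Cn2cc(-c3ccc4c(N)n[nH]c4c3)ccc2=O)c1`: 8 nM
compound 3 `Nc1n[nH]c2cc(-c3ccc(=O)n(Cc4cccc(F)c4)c3)ccc12`: 5 nM

In an assay for inhibition of MAP kinase-interacting serine/threonine-protein kinase 2 (Homo sapiens), read by luminescence and ADP-Glo, with a stated time of 2 h (a higher number here means a weaker inhibitor, a lower number a stronger inhibitor), compound 1 gives 100 nM, the highest of the three numbers. Among the compounds with values here, compound 2 gives 8 nM and compound 3 gives 5 nM, and both gaps to compound 1 lie beyond the scatter; for these pairs no single-point step is defined, so only the values themselves speak.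

Compound 4 `O=c1ccc(-c2ccc3cn[nH]c3c2)cn1Cc1ccccc1F` differs from compound 1 in one place: fluoro in place of trifluoromethyl on an aromatic carbon. Within the data shown here, the one measured step, a 1.6-fold lower number from compound 2 to compound 3 (0.20 log units; within the scatter), concerns a different pair of groups on a different core and sits within the scatter; it does not match the change from compound 1 to compound 4 and offers no direct guide. Among the measured compounds shown here, no measured pair shows trifluoromethyl against fluoro at this position. The expectation therefore rests on compound 1 alone, and the step is expected to be small: a 1.1-fold higher number from compound 1 to compound 4 (0.04 log units; within the scatter), within the scatter. Compound 4 is estimated at 110 nM, with a range from 40 nM to 320 nM.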

Compound 4, half-maximal inhibitory concentration: 37 nM
The estimate for compound 4 lay 3.0-fold (0.47 log units) above the measured number; measured number below the stated range.
By their numbers in this assay, from the lowest: compounds 3 and 2 (each within the scatter of the next); then compound 4; then compound 1.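

In this assay, the change at this position is a real one: fluoro in place of trifluoromethyl, on an aromatic carbon ortho to a large group, gives a 2.7-fold lower number from compound 1 to compound 4 (0.43 log units; beyond the scatter) on the core of compound 1. Within the data shown here, this is the first pair to isolate this position, and it shows that the number responds to the group placed there and that trifluoromethyl is not required, since fluoro gives the lower number. No measurement shown accounts for this step.

On these data alone, only these two groups have been compared at this position, so it remains open how chloro, methoxy or a nitrile would fare there. Also open, as far as these compounds go, is whether the same change would give a step of similar size on the core of compound 3.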